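Swapping chloro for trifluoromethyl on a benzyl ring

This account rests on a few compounds, and the source may have more. Where it says the series, first, only, none or still open, it means among the compounds named here.

Of the compounds shown here, two share a core and have been measured in an assay for inhibition of MAP kinase-interacting serine/threonine-protein kinase 2 (Homo sapiens), read by luminescence and ADP-Glo, with a stated time of 2 h; a higher number here means a weaker inhibitor, a lower number a stronger inhibitor. Compound 1 `Nc1n[nH]c2cc(-c3ccc(=O)n(Cc4cccc(Cl)c4)c3)ccc12` gives 6 nM, the lower of the two numbers. Among the compounds with values here, compound 2 `O=c1ccc(-c2ccc3cn[nH]c3c2)cn1Cc1cccc(Cl)c1` gives 40 nM; the only change is a 6.7-fold higher number from compound 1 to compound 2 (0.82 log units; beyond the scatter). The new compound 3 `Nc1n[nH]c2cc(-c3ccc(=O)n(Cc4cccc(C(F)(F)F)c4)c3)ccc12` differs from compound 1 in one place: trifluoromethyl in place of chloro on an aromatic carbon. Within the data shown here, none of the measured steps touch this position, since the only one known concerns the amino group on the core, so there is no direct guide to the size or direction of the effect. With nothing pointing either way, the expected outcome for compound 3 in this assay is a step of about a 1.3-fold higher number from compound 1 to compound 3 (0.12 log units; within the scatter), which lies within the usual scatter. On that basis compound 3 is estimated at 8 nM, with a range from 3 nM to 25 nM.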

Compound 3, half-maximal inhibitory concentration: 21 nM
Compound 3: middle estimate off by 2.6-fold (0.42 log units), on the low side; measured number inside the range.
By their numbers in this assay, from the lowest: compound 1; then compounds 3 and 2 (each within the scatter of the next).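

Swapping one group on the benzyl ring matters: in this assay, trifluoromethyl in place of chloro gives a 3.5-fold higher number from compound 1 to compound 3 (0.54 log units; beyond the scatter). Within the data shown here, the only earlier step concerned the amino group on the core, so this is the first sign that this aromatic carbon, meta to a large group, also affects the number. Of the two groups seen here with the amino group in place, chloro gives the lower number and so the stronger inhibitor. No measurement shown here accounts for this step.

The compounds shown leave open how a methoxy group, a nitrile or a plain hydrogen on this carbon would compare with chloro. They also leave open whether the same swap would give a similar step on the core of compound 2, which lacks the amino group.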